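The source may hold more compounds than are shown below. What is called first, only, known or untested is meant among the compounds shown, and "the series" means these compounds.

Measured in a functional assay on CAL-27 cells (Homo sapiens) for cytotoxicity, read by MTT assay, with a stated time of 72 h; on this read-out higher numbers stand for weaker inhibition and lower numbers for stronger inhibition:
- compound 1 `Cc1cc(C)cc(C(=O)N(CCCCCC(=O)Nc2ccccc2N)CC(=O)NC2CCCCC2)c1`: 17500 nM
- compound 2 `Cc1cc(C)cc(C(=O)N(CC(=O)NCc2ccccc2)Cc2ccc(C(=O)Nc3cc(-c4ccccc4)ccc3N)cc2)c1`: 8900 nM
- compound 3 `Nc1ccccc1NC(=O)CCCCCN(CC(=O)NCc1ccccc1)C(=O)c1cccc2ccccc12`: 11000 nM

Compound 2, at 8900 nM, cannot be told apart from the other two compounds, since all three values lie within the usual scatter of repeated measurements. Compound 4 `Cc1cc(C)cc(C(=O)N(CC(=O)NCc2ccccc2)Cc2ccc(C(=O)Nc3ccccc3N)cc2)c1` has hydrogen in place of phenyl on an aromatic carbon, para to an amino group. Going by the values given here, no two measured compounds differ in one place only, so the effect of this change has not been seen directly. Compound 3 also lacks this phenyl and gives 11000 nM, so no change beyond the scatter is expected in this assay. The expected result is a small step of a 1.2-fold lower number from compound 2 to compound 4 (0.07 log units; within the scatter). The estimated value for compound 4 is 7500 nM, with an expected range of 2800 nM to 20000 nM.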

Compound 4, half-maximal inhibitory concentration: 1600 nM
Compound 4: middle estimate off by 4.7-fold (0.67 log units), on the high side; measured number below the stated range.
By their numbers in this assay, from the lowest: compound 4; then compounds 2, 3 and 1 (each within the scatter of the next).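

In this assay, putting hydrogen in place of phenyl on this aromatic carbon, para to an amino group, gives a 5.6-fold lower number from compound 2 to compound 4 (0.75 log units; beyond the scatter) and nothing else in the molecule changes. Going by these compounds alone, this is the first direct reading of the change, and it shows that at this position, on this core, the compound with hydrogen gives the stronger inhibition of the two. No measurement here explains the step. From the compounds shown here alone, whether a fluorine atom, a methyl group or a methoxy group on this carbon would behave like hydrogen or like phenyl remains open.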